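The compounds below may be only part of what the source reports. "The series", "measured", "known", "first", "only" and "open" are said of these compounds alone.

Compound 3 `O=S(=O)(Nc1nccs1)c1ccc(N/C(S)=N\c2ccnc3cc(C(F)(F)F)ccc23)cc1` is one of three close relatives built on a shared core. In a functional assay on LoVo cells (Homo sapiens) for antiproliferative activity, read by sulforhodamine B assay, with a stated time of 48 h (a higher number here means a weaker inhibitor, a lower number a stronger inhibitor), compound 3 gives 67100 nM, the higher of the two numbers reported so far. Its nearest neighbour by number is compound 1 `Nc1ccc(S(=O)(=O)Nc2ccnc3cc(C(F)(F)F)ccc23)cc1`, which in this assay gives 53700 nM; the two values lie within the usual scatter of each other, so no order between them can be claimed. Compound 2 `Cc1cc(NS(=O)(=O)c2ccc(N/C(S)=N\c3ccnc4cc(C(F)(F)F)ccc34)cc2)on1` in this assay is reported as "not active" (no number reported), with no number attached.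

Compound 4 `COc1cc(NS(=O)(=O)c2ccc(N/C(S)=N\c3ccnc4cc(C(F)(F)F)ccc34)cc2)nc(OC)n1` differs from compound 3 in one place: 2,6-dimethoxypyrimidin-4-yl in place of 1,3-thiazol-2-yl on a sulfonamide nitrogen. Among the compounds with values here, no step between two measured compounds of this set is available to calibrate such a change, and the only numbers known sit close together, with compound 2 giving no number at all. The step from compound 3 to compound 4 is therefore expected to stay small, in either direction or none beyond the scatter, as a 1.0-fold higher number from compound 3 to compound 4 (0.02 log units; within the scatter). Compound 4 is expected to give about 70000 nM in this assay, within a range from 25000 nM to 200000 nM.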

Compound 4, half-maximal inhibitory concentration: 76700 nM
Estimate against measurement, compound 4: 1.1-fold (0.04 log units) below, within the range that was stated.
By their numbers in this assay, from the lowest: compounds 1, 3 and 4 (each within the scatter of the next).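

Within the data shown here, this is the first pair in the set that differs in one place only, so it gives the first direct reading of a change on the sulfonamide nitrogen. In this assay, putting 2,6-dimethoxypyrimidin-4-yl, a six-membered aromatic ring, in place of 1,3-thiazol-2-yl, a smaller five-membered aromatic ring, gives a 1.1-fold higher number from compound 3 to compound 4 (0.06 log units; within the scatter) and so produces no readable change, even though the group entering is the larger one. Nothing measured here speaks to the reason for this result.

Still open, from the compounds shown here alone, is how the number responds when the group on this nitrogen is not an aromatic ring, such as a plain methyl group or a longer alkyl chain. A single step also cannot show whether any other group at this position would move the number beyond the scatter.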